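Compound 2 gains a second benzyl

This account rests on a few compounds, and the source may have more. Where it says the series, first, only, none or still open, it means among the compounds named here.

In a functional assay on CNE2Z cells (Homo sapiens) for inhibition, read by MTT assay, with a stated time of 72 h (on this read-out higher numbers stand for weaker inhibition and lower numbers for stronger inhibition), compound 1 (`C=CCc1ccc(O)c(-c2ccc(OCc3ccccc3)c(CC=C)c2)c1`) gives 30300 nM and compound 2 (`C=CCc1ccc(OCc2ccccc2)c(-c2ccc(O)c(CC=C)c2)c1`) gives 24000 nM, so these two values stand within the usual scatter of each other. Compound 3 (`C=CCc1ccc(OCc2ccccc2)c(-c2ccc(OCc3ccccc3)c(CC=C)c2)c1`) has benzyl in place of hydrogen on an oxygen on an aromatic ring of compound 2, which turns hydroxy to benzyloxy (benzyl in place of hydrogen on an oxygen on an aromatic ring). Going by the values given here, no measured pair shows this change, so any forecast is uncertain. In this assay the expected change is small and toward weaker inhibition, with a 1.5-fold higher number from compound 2 to compound 3 (0.16 log units; within the scatter) as the estimated step. Compound 3 is expected at 35000 nM with an estimated range from 12000 nM to 100000 nM for this measurement.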

Compound 3, half-maximal inhibitory concentration: > 50000 nM
Compound 3: only a limit was reported; the forecaster's own chance of this, stated with the estimate: 20%; middle value at least 1.4-fold (0.15 log units) from the limit.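

Going by these compounds alone, compounds 1 and 2 each keep one hydroxy, and compound 3 keeps none, so this is the first look at losing the remaining one. In this assay, changing hydroxy to benzyloxy weakens inhibition, with an at least 2.0-fold higher number from compound 2 to compound 3 (0.31 log units; beyond the scatter), while the other route gives an at least 1.6-fold higher number from compound 1 to compound 3 (0.21 log units; that floor lies within the scatter), whose floor alone does not settle the change. Compound 3 has only a limit, not a number: the limit of > 50000 nM in this assay, at which 1 of the 3 values shown sits.

From the compounds shown here alone, the true size of the loss stays unknown. Also open, going by these compounds, is whether a methyl on that oxygen, or an amine in place of the hydroxy, would keep inhibition.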